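The compounds below may be only part of what the source reports. "The series", "measured", "known", "first", "only" and "open" are said of these compounds alone.

Measured so far in an ADME assay on Vero cells (Chlorocebus sabaeus) for cytotoxicity, read by sulforhodamine B assay, with a stated time of 72 h; a lower number here means a stronger inhibitor, a higher number a weaker inhibitor:

Compound 1, `COc1ccc2c(c1)[C@@H](O)CN(C)C2`, gives > 100000 nM, which is a limit of this assay rather than a number.
Compound 2, `CN1Cc2ccc(OCc3ccccc3)cc2[C@@H](O)C1`, gives > 100000 nM, again a limit.
Compound 3, `COc1cccc2c1CN(C)C[C@@H]2O`, gives > 100000 nM, also a limit.

The change from compound 1 to compound 2 is phenyl in place of hydrogen on a saturated chain carbon bound to an oxygen on an aromatic ring. Because both values are limits, the size of this step cannot be read: a step that the two limits leave unreadable from compound 1 to compound 2. Compound 3 shares its atoms with compound 1 but joins them differently; how the two cores differ is not broken down here. Compound 4, `CN1Cc2c(OCc3ccccc3)cccc2[C@@H](O)C1`, has not yet been measured in this assay. It arises from compound 3 by the same change, (phenyl in place of hydrogen on a saturated chain carbon bound to an oxygen on an aromatic ring), at the same kind of place.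

Within the data shown here, all three measured values sit at the same point, (the limit of > 100000 nM in this assay, at which 3 of the 3 values shown sit), so no step among them can be sized, and none of the three can be called stronger or weaker than another. Since no readable step is known, the step from compound 3 to compound 4 is expected to be small, a number no higher from compound 3 to compound 4 (the limit leaves the size open), resting only on the observation that the same change from compound 1 to compound 2 left the value at the limit. Compound 4 is therefore estimated at 100000 nM, with the range 40000 nM to 300000 nM, and most likely the assay will again report only a limit.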

Compound 4, half-maximal inhibitory concentration: > 100000 nM
Compound 4 gave a limit, no number; the forecaster's own chance of this, stated with the estimate: 85%; the middle value sits exactly at the limit.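

In this assay compound 4 gives > 100000 nM, which is a limit of the assay and not a number. Compound 3 stands at the same limit, so no step between compound 3 and compound 4 can be read: the limit of > 100000 nM in this assay, at which 4 of the 4 values shown sit.

The compounds shown leave open how far past this limit each one lies, and whether the phenyl change shifts the value at all.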